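The source may hold more compounds than are shown below. What is called first, only, known or untested is meant among the compounds shown, and "the series" means these compounds.

Of the compounds shown here, two of a shared core have been tested in an ADME assay on Vero cells (Chlorocebus sabaeus) for cytotoxicity, read by resazurin assay, with a stated time of 3 days; a higher number here means a weaker inhibitor, a lower number a stronger inhibitor. Compound 1 `CCN(CC)c1cc2[nH]c(C3CCCCC3)nc2cc1NC(=O)c1cnccn1` gives in this assay only a limit, > 100 ug/mL. Compound 2 `CCCNC(=O)Nc1cc2nc(C3CCCCC3)[nH]c2cc1N1CCCC1` likewise gives only a limit in this assay, > 100 ug/mL. Both values therefore sit at the same point, namely (the limit of > 100 ug/mL in this assay, at which 2 of the 2 values shown sit), so compound 2 stands nowhere above or below its companion on the numbers shown; no step between measured compounds can be described.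

Compound 3 `Cc1ccc(C(=O)Nc2cc3nc(C4CCCCC4)[nH]c3cc2N2CCCC2)cc1` differs from compound 2 in one place: 4-methylphenyl in place of propylamino on a carbonyl carbon. Since both measured compounds sit at a limit, the step from compound 2 to compound 3 in this assay is expected to be none beyond the scatter, and the estimate for that step is a number no higher from compound 2 to compound 3 (the limit leaves the size open). Compound 3 is accordingly expected to give about 100 ug/mL in this assay, within a range from 40 ug/mL to 150 ug/mL.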

Compound 3, half-maximal inhibitory concentration: > 100 ug/mL
Compound 3 ended at the assay's limit; the forecaster's own chance of this, stated with the estimate: 65%; the middle value sits exactly at the limit.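

The step from compound 2 to compound 3 cannot be read in this assay, because both compounds sit at the same limit: the limit of > 100 ug/mL in this assay, at which 3 of the 3 values shown sit.

The compounds shown leave open what actual values lie behind these limits, and whether 4-methylphenyl in place of propylamino on a carbonyl carbon changes the read-out at all.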